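Cyano removal on the phenyl of compound 2

This account rests on a few compounds, and the source may have more. Where it says the series, first, only, none or still open, it means among the compounds named here.

Measured set in an assay on HEK293 cells for displacement of a labelled ligand from tyrosine-protein kinase receptor UFO (Homo sapiens), read by NanoBRET, with a stated time of 2 h; a higher number here means a weaker inhibitor, a lower number a stronger inhibitor:
- compound 2 `N#Cc1ccc(-n2cc(-c3n[nH]c4cc(Cl)c(N[C@@H]5CCNC5)cc34)cn2)cc1`; in this assay compound 2 gives 880 nM
- compound 3 `CN1CC[C@@H](Nc2cc3c(-c4cnn(C)c4)n[nH]c3cc2Cl)C1`; in this assay compound 3 gives 8960 nM
- compound 1 `CN1CCC(CNc2ccc3[nH]nc(-c4cnn(C)c4)c3c2)CC1`; in this assay compound 1 gives "not determined" (no result reported), so no result was reported for it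

Compound 2 holds the lower of the two numbers. Compound 3 stands at a higher number, and the gap between compound 2 and compound 3 lies beyond the usual scatter. Among the measured compounds shown here, the two compounds differ in more than one place, so no single structural step is drawn between them; only the two values themselves are noted.

Compound 4 `Clc1cc2[nH]nc(-c3cnn(-c4ccccc4)c3)c2cc1N[C@@H]1CCNC1` differs from compound 2 in one place: hydrogen in place of cyano on an aromatic carbon. For the measured compounds named here, since no step between measured compounds matches this change, its size and direction can only be expected, not read off. The cyano is a small group, and its loss is expected to cost some potency without changing the series markedly; the step from compound 2 to compound 4 in this assay is expected to be a 2.0-fold higher number from compound 2 to compound 4 (0.31 log units; beyond the scatter), a modest rise in the number. Compound 4 is therefore estimated at 1800 nM, with a range of 600 nM to 5500 nM.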

Compound 4, half-maximal inhibitory concentration: 668 nM
The estimate for compound 4 lay 2.7-fold (0.43 log units) above the measured number, within the range that was stated.
By their numbers in this assay, from the lowest: compounds 4 and 2 (each within the scatter of the next); then compound 3.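

In this assay, among the compounds shown here, the change from 4-cyanophenyl to phenyl is the first single-place step, and it gives a 1.3-fold lower number from compound 2 to compound 4 (0.12 log units; within the scatter). The nitrile on an aromatic carbon para to a large group can therefore give way to hydrogen with no difference in this read-out that stands clear of the scatter, so potency at this level does not depend on that group. Nothing measured here offers a reason for this result.

Open, as far as these compounds go, is how other groups at this same carbon would read, such as a methoxy, a carboxylic acid, a primary amine or a longer chain ending in an amine. Also open, from the compounds shown here alone, is whether the step keeps its size when the pyrrolidine amine on the shared core is replaced by another amine, such as a piperidine.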